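The compounds below may be only part of what the source reports. "The series", "measured", "known", "first", "only" and "open" are said of these compounds alone.

Three compounds of the series have numbers in an assay on CHO cells for antagonist activity at transient receptor potential cation channel subfamily V member 1 (Homo sapiens), read by FLIPR; a lower number here means a stronger inhibitor, a higher number a weaker inhibitor. Compound 1 `CC(C(=O)NCc1ccc(C(F)(F)F)nc1-c1ccccc1)c1ccc(NS(C)(=O)=O)c(F)c1` gives 6.4 nM. Compound 2 `CC(C(=O)NCc1ccc(C(F)(F)F)nc1-c1ccsc1)c1ccc(NS(C)(=O)=O)c(F)c1` gives 2 nM. Compound 3 `CC(C(=O)NCc1ccc(C(F)(F)F)nc1-c1ccoc1)c1ccc(NS(C)(=O)=O)c(F)c1` gives 1.4 nM, the lowest of the three numbers; its gap to compound 2 lies within the scatter, its gap to compound 1 beyond it. The two measured steps at this aromatic carbon are a 3.2-fold lower number from compound 1 to compound 2 (0.51 log units; beyond the scatter) and a 4.6-fold lower number from compound 1 to compound 3 (0.66 log units; beyond the scatter), both modest and both replacing phenyl by a five-membered aromatic ring with one hetero atom. Compound 4 `CC(C(=O)NCc1ccc(C(F)(F)F)nc1C#Cc1ccccc1)c1ccc(NS(C)(=O)=O)c(F)c1` carries 2-phenylethynyl in place of furan-3-yl on an aromatic carbon. Going by the values given here, neither measured step covers a group of this kind: a six-membered ring of carbon only returns, now joined through a triple bond, and no compound shows such a linkage. Among the compounds with values here, the only guide is that phenyl in compound 1 gave 6.4 nM. A modest rise in number from compound 3 is therefore expected, a 7.1-fold higher number from compound 3 to compound 4 (0.85 log units; beyond the scatter), with wide uncertainty. Compound 4 is estimated at 10 nM, in the range 3 nM to 40 nM.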

Compound 4, inhibition constant: 0.8 nM
Compound 4: the middle estimate sits 13-fold (1.10 log units) above what was measured; measured number below the stated range.
By their numbers in this assay, from the lowest: compounds 4, 3 and 2 (each within the scatter of the next, the first and the last beyond it); then compound 1.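

In this assay, the aromatic carbon next to the ring nitrogen accepts a phenyl ring carried through a triple bond, and 2-phenylethynyl stays within the scatter of furan-3-yl (a 1.8-fold lower number from compound 3 to compound 4 (0.24 log units; within the scatter)). The same group stands clearly apart from directly attached phenyl (an 8.0-fold lower number from compound 1 to compound 4 (0.90 log units; beyond the scatter)) and from thiophen-3-yl (a 2.5-fold lower number from compound 2 to compound 4 (0.40 log units; beyond the scatter)), so a six-membered carbon ring at this position does not by itself go with the highest number of the series. No measurement at hand accounts for these steps.

Still open, going by these compounds, is how a cyclohexyl ring, a longer alkyne chain or a dialkylamine at this carbon would read in this assay, and whether substituents on the phenyl of 2-phenylethynyl move the number. On these data alone, all four compounds share the rest of the core, so whether these steps hold with other groups elsewhere also remains open.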